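The source may hold more compounds than are shown below. What is called first, only, known or untested is meant among the compounds shown, and "the series" means these compounds.

Measured compounds:
compound 1, `Cc1cc(Nc2nc(NCc3ccc(F)cc3F)nc3ccccc23)n[nH]1`: 200 nM
compound 2, `Fc1ccc(CNc2nc(Nc3cc(C4CC4)[nH]n3)c3ccccc3n2)c(F)c1`: 4.7 nM
compound 3, `CCc1cc(Nc2nc(NCc3ccc(F)cc3F)nc3ccccc23)n[nH]1`: 20 nM

In an assay for inhibition of high affinity nerve growth factor receptor (Homo sapiens), read by HTRF, with a stated time of 30 min, in the presence of a further agent that is not named here (a lower number here means a stronger inhibitor, a higher number a weaker inhibitor), compound 2 gives the lowest number of the three, and the two others stand clearly apart from it: a 4.3-fold higher number from compound 2 to compound 3 (0.63 log units; beyond the scatter), and a 43-fold lower number from compound 1 to compound 2 (1.63 log units; beyond the scatter). The third comparison, a 10-fold lower number from compound 1 to compound 3 (1.00 log units; beyond the scatter), is also beyond the scatter. All three of these steps concern the small group on the ring that is joined to the shared core through a nitrogen; nothing else was varied among the measured compounds.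

Compound 4, `Fc1ccc(CNc2nc(Nc3cc(C4CC4)[nH]n3)c3cc(Br)ccc3n2)c(F)c1`, has not yet been measured. It differs from compound 2 in a single place: bromo in place of hydrogen on an aromatic carbon. Within the data shown here, no measured step touches that six-membered ring, so the measured compounds give no direct guide to what this change does. The expectation therefore rests on the fact that compound 4 keeps unchanged everything that carried the measured differences, and the step is estimated as a 1.3-fold higher number from compound 2 to compound 4 (0.11 log units; within the scatter), which amounts to no step beyond the scatter, with a wide range to reflect the missing guide. Compound 4 is expected to give about 6 nM in this assay, between 1.5 nM and 25 nM.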

Compound 4, half-maximal inhibitory concentration: 120 nM
For compound 4 the middle estimate is 20-fold (1.30 log units) below the measured one, and the stated range ends below it.
By their numbers in this assay, from the lowest: compound 2; then compound 3; then compounds 4 and 1 (each within the scatter of the next).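

In this assay, among these compounds, the earlier compounds differ only in the small group on the ring joined to the shared core through a nitrogen, so they say nothing about the six-membered aromatic ring of carbon only. This result shows that the number also responds strongly to a change on that ring: bromo in place of hydrogen on one of its aromatic carbons gives a 26-fold higher number from compound 2 to compound 4 (1.41 log units; beyond the scatter), a single added heavy atom producing a step of the same large class as a 43-fold lower number from compound 1 to compound 2 (1.63 log units; beyond the scatter). Nothing measured here bears on what lies behind this step.

The compounds shown leave open whether the step belongs to bromo itself or would follow any group on this carbon, something a fluoro, a methoxy or an amine at the same place would help to settle, as would bromo on another carbon of this ring. They also leave open whether bromo would have a similar effect with methyl or ethyl in place of cyclopropyl on the ring joined through the nitrogen.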